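The source may report more compounds than this note shows. Statements on the series, on what has been measured and on what is new or still open speak of the compounds shown alone.

Measured compounds in the series:

compound 1, `CC(C)C[C@H](N)CN(C(=O)[C@@H]1C[C@H]1c1ccccc1)c1ccc(-c2ccccc2)cc1`, 880 nM in a functional assay for agonist activity at G protein-coupled receptor 88 (Homo sapiens), read by HTRF and cAMP accumulation; a higher number here means that more compound is needed for the effect, a lower number that less compound is needed
compound 2, `CC(C)C[C@H](N)CCN(C(=O)[C@@H]1C[C@H]1c1ccccc1)c1ccc(-c2ccccc2)cc1`, 3 nM
compound 3, `CC[C@H](C)[C@H](N)CN(C(=O)[C@@H]1C[C@H]1c1cccc(Cl)c1)c1ccc(-c2ccccc2)cc1`, 2200 nM

Compound 3 gives the highest number of the three measured compounds in this assay; its nearest neighbour is compound 1, and compound 2 lies far from it. Compound 3 differs from compound 1 both in the chain bearing the amine and in the chlorine on the aryl ring of the cyclopropane, so no single change can be read from those two values.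

Compound 4, `CC[C@H](C)[C@H](N)CN(C(=O)[C@@H]1C[C@H]1c1ncccn1)c1ccc(-c2ccccc2)cc1`, is the next compound to be measured. Its difference from compound 3: pyrimidin-2-yl in place of 3-chlorophenyl on a saturated ring carbon

Among the compounds with values here, the only step measured in one place is a 290-fold lower number from compound 1 to compound 2 (2.47 log units; beyond the scatter), which concerns the chain between the amine and the amide nitrogen, not the aryl ring on the cyclopropane. It therefore says nothing directly about the change from compound 3 to compound 4. Within the data shown here, no measured pair replaces the aryl ring on the cyclopropane with a heteroaryl, so the direction of this step is open. With the chain of compound 3 unchanged and compound 3 already the weakest measured, the working expectation is a modest move toward a higher number, within a broad range, expressed as a 1.8-fold higher number from compound 3 to compound 4 (0.26 log units; within the scatter).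

Compound 4 is thus estimated at 4000 nM in this assay, with an expected range from 800 nM to 20000 nM.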

Compound 4, half-maximal effective concentration: 130 nM
Compound 4: middle estimate off by 31-fold (1.49 log units), on the high side; the measured number lies below the stated range.
By their numbers in this assay, from the lowest: compound 2; then compound 4; then compound 1; then compound 3.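

In this assay, pyrimidin-2-yl in place of 3-chlorophenyl on the saturated ring carbon gives a 17-fold lower number from compound 3 to compound 4 (1.23 log units; beyond the scatter), so the group on this cyclopropyl carbon strongly affects the read-out and a carbon-only aromatic ring is not required there. Within the data shown here, until now the only step read in one place was a 290-fold lower number from compound 1 to compound 2 (2.47 log units; beyond the scatter), in the chain bearing the amine, so the series now has a large step at a second site of the molecule. The change removes the chlorine and also brings in two ring nitrogens with their 2 hydrogen-bond acceptors, and no measurement at hand bears on why the number falls.

The compounds shown leave open whether the step follows from losing the chlorine or from gaining the ring nitrogens, a question that unsubstituted phenyl or pyridin-2-yl on the chain of compound 4 would address. They also leave open whether pyrimidin-2-yl gives a similar step on the 2-amino-4-methylpentyl chain of compound 2.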